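Bromo in Place of Chloro on the Shared Core

A few compounds are considered here, and "the series" means these few. Any claim that something is new, unique, unknown or untested is made for them only; others in the source may bear on it.

Measured in a functional assay on MCF7 cells (Homo sapiens) for antiproliferative activity, read by MTT assay, with a stated time of 48 h; on this read-out lower numbers stand for stronger inhibition and higher numbers for weaker inhibition:
compound 1 `Fc1ccc2[nH]c(-c3cn(-c4ccccc4)nc3-c3ccccc3)nc2c1`: 2430 nM
compound 2 `Clc1ccc2[nH]c(-c3cn(-c4ccccc4)nc3-c3ccccc3)nc2c1`: 1960 nM

On these numbers, compound 2 at 1960 nM stands within the scatter of compound 1, so the two cannot be ranked. The next compound is compound 3 `Brc1ccc2[nH]c(-c3cn(-c4ccccc4)nc3-c3ccccc3)nc2c1`, which keeps the shared core and differs from compound 2 in one group: bromo in place of chloro on an aromatic carbon. Among the compounds with values here, only one measured step bears on this change, chloro in place of fluoro on an aromatic carbon, a 1.2-fold lower number from compound 1 to compound 2 (0.09 log units; within the scatter). That step did not leave the scatter, so no step beyond the scatter is expected in this assay, and neither direction is favoured. The expected size of the step is a 1.0-fold lower number from compound 2 to compound 3 (0.01 log units; within the scatter). For compound 3 the estimated value is 1900 nM, with an expected range from 1000 nM to 3600 nM.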

Compound 3, half-maximal inhibitory concentration: 830 nM
Compound 3: middle estimate off by 2.3-fold (0.36 log units), on the high side, and the stated range ends above it.
By their numbers in this assay, from the lowest: compound 3; then compounds 2 and 1 (each within the scatter of the next).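

In this assay, the identity of the halogen on this aromatic carbon now matters beyond the scatter, as bromo in place of chloro gives a modest step (a 2.4-fold lower number from compound 2 to compound 3 (0.37 log units; beyond the scatter)), whereas the earlier exchange of chloro for fluoro could not be told from the scatter. The same holds when bromo is set against fluoro (a 2.9-fold lower number from compound 1 to compound 3 (0.47 log units; beyond the scatter)), so compound 3 has the lowest number of the three, and the response at this position does not follow one even step across the halogens shown. Nothing available here explains why bromo differs from the two lighter halogens. The compounds shown leave open whether iodo would continue this trend or whether a non-halogen group such as methyl, methoxy or nitrile could match bromo here. They also leave open whether the bromo step would hold on the other aromatic carbons of the shared core.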